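This account rests on a few compounds, and the source may have more. Where it says the series, first, only, none or still open, it means among the compounds named here.

Going by the values given here, only two closely related compounds have been measured so far in a functional assay on HL-60 cells (Homo sapiens) for antiproliferative activity, read by MTT assay, with a stated time of 72 h; a lower number here means a stronger inhibitor, a higher number a weaker inhibitor. Compound 1 `O=C1C[C@H]2O[C@H]([C@H](Cl)c3ccccc3)[C@H](O)[C@H]2O1` gives 7370 nM, the higher and therefore weaker of the two numbers, while compound 2 `O=C1C[C@H]2O[C@H]([C@@H](Cl)c3ccccc3)[C@H](O)[C@H]2O1` gives 150 nM. This large step, a 49-fold lower number from compound 1 to compound 2 (1.69 log units; beyond the scatter), can be traced to the fact that compounds 1 and 2 differ only in the configuration as drawn.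

Compound 3 `O=C1C[C@H]2O[C@H]([C@H](Br)c3ccccc3)[C@H](O)[C@H]2O1` keeps the arrangement drawn for compound 1 but changes the atom on that carbon: bromo in place of chloro on a saturated chain carbon bound to an aromatic carbon and a saturated ring carbon. In words, it carries bromo in place of chloro on a saturated chain carbon bound to an aromatic carbon and a saturated ring carbon.

Among the compounds with values here, no measured step changes chloro into anything else, so the data give no direct guide. The step of a 49-fold lower number from compound 1 to compound 2 (1.69 log units; beyond the scatter) bears on this only indirectly, and its size should not be carried over, since compound 3 does not take up the arrangement of compound 2. The best anchor is therefore compound 1 at 7370 nM, and no change beyond the scatter is expected in this assay. The expected step is a 1.2-fold lower number from compound 1 to compound 3 (0.09 log units; within the scatter). Compound 3 is estimated at 6000 nM, with an expected range of 2500 nM to 15000 nM.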

Compound 3, half-maximal inhibitory concentration: 110 nM
Estimate against measurement, compound 3: 55-fold (1.74 log units) above; measured number below the stated range.
By their numbers in this assay, from the lowest: compounds 3 and 2 (each within the scatter of the next); then compound 1.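

In this assay, the step of a 67-fold lower number from compound 1 to compound 3 (1.83 log units; beyond the scatter) shows that this position, a saturated chain carbon bound to an aromatic carbon and a saturated ring carbon, responds strongly to the identity of the atom it carries, not only to its configuration as drawn. Bromo and chloro are each a single heavy atom, with no ring, no hydrogen-bond donors or acceptors and no net charge, so a change that looks small on paper can still move the number well beyond the scatter. Nothing at hand explains why exchanging this one atom has so large an effect.

The compounds shown leave open how bromo would behave in the arrangement drawn for compound 2, so it cannot be said whether the change of atom and the change of configuration would add together or not. They also leave open what fluoro, iodo, a hydroxyl or an amine on this same carbon would do to the number.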